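A few compounds are considered here, and "the series" means these few. Any claim that something is new, unique, unknown or untested is made for them only; others in the source may bear on it.

In a physicochemical assay for solubility, in phosphate buffer, measured as kinetic solubility, at pH 7.4, tested at 250 uM (a lower number here means a less soluble compound, a higher number a more soluble compound), compound 1 `CCCCNc1ccc([N+](=O)[O-])cc1S(N)(=O)=O` gives 85000 nM, and compound 2 `CCCCCCNc1ccc([N+](=O)[O-])cc1S(N)(=O)=O` gives 6000 nM, the lower of the two numbers. Compound 3 `CCCCCCNc1ccc([N+](=O)[O-])cc1S(=O)(=O)N(C)C` keeps the chain of compound 2 but differs elsewhere, with dimethylamino in place of amino on a sulfonyl sulfur. For the measured compounds named here, no measured pair tests this change directly. Going by the values given here, the one measured step that bears on it, a 14-fold lower number from compound 1 to compound 2 (1.15 log units; beyond the scatter), also added carbon, there as ethyl in place of hydrogen on a saturated chain carbon, and that step was large. The new change sits at a different place, so this is only a loose guide. A further, smaller drop in this assay is expected, and the estimated step is a 2.4-fold lower number from compound 2 to compound 3 (0.38 log units; beyond the scatter). For compound 3 the expected value is 2500 nM, with an estimated range from 600 nM to 9000 nM.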

Compound 3, solubility: 1000 nM
Compound 3: the middle estimate sits 2.5-fold (0.40 log units) above what was measured; low and high end bracket the measured number.
By their numbers in this assay, from the lowest: compound 3; then compound 2; then compound 1.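

In this assay the swap of amino for dimethylamino on the sulfonyl sulfur gives a 6.0-fold lower number from compound 2 to compound 3 (0.78 log units; beyond the scatter) and so shows that this end of the molecule, not only the chain, shifts the read-out. The swap takes away the 1 hydrogen-bond donor of amino and adds 2 carbons in a single step, so the two differences cannot be told apart here. Nothing measured here accounts for the drop.

Methylamino on the same sulfonyl sulfur, which would add a single methyl and keep a hydrogen on the nitrogen, could begin to separate those two differences. As far as these compounds go, it also remains open whether dimethylamino would give a step of similar size on the shorter chain of compound 1.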